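The compounds below may be only part of what the source reports. "The series", "measured", "known", "first", "only" and "open" are said of these compounds alone.

Measured so far in a functional assay on CHO cells for agonist activity at Alpha-1D adrenergic receptor (Homo sapiens), read by FLIPR and calcium flux; a lower number here means that less compound is needed, a higher number that more compound is needed for the effect: compound 1 `c1cc(-c2nccs2)c2c(c1)C(c1ncc[nH]1)CC2` gives 3190 nM; compound 2 `Cc1n[nH]cc1-c1cccc2c1CCC2c1ncc[nH]1` gives 634 nM.

Among the compounds with values here, compound 2 stands lowest of the two numbers in this assay; its only neighbour is compound 1, and the step of a 5.0-fold lower number from compound 1 to compound 2 (0.70 log units; beyond the scatter) lies beyond the scatter. Compound 3 `CNC(=O)c1cccc2c1CCC2c1ncc[nH]1` awaits measurement. The change from compound 2 is methylcarbamoyl in place of 3-methyl-1H-pyrazol-4-yl on an aromatic carbon. Within the data shown here, only one measured step bears on this, and only loosely: from compound 1 to compound 2 one five-membered aromatic ring replaced another, whereas here the ring is lost altogether and a methylcarbamoyl enters. That step gives no direct guide to removing the ring. An upward move in this assay is expected, toward the higher number seen for compound 1, though the uncertainty is wide. Compound 3 is therefore estimated at 2500 nM, within 600 nM to 10000 nM. The expected step is a 3.9-fold higher number from compound 2 to compound 3 (0.60 log units; beyond the scatter).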

Compound 3, half-maximal effective concentration: > 10000 nM
Compound 3: no number, only a limit (the forecaster's own chance of this, stated with the estimate: 20%); at least 4.0-fold (0.60 log units) between middle value and limit.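

In this assay compound 3 stands at > 10000 nM, which is a limit of the assay and not a number. Against the two ring-bearing compounds, methylcarbamoyl on this aromatic carbon gives an at least 15-fold higher number from compound 2 to compound 3 (1.19 log units; beyond the scatter) and an at least 3.1-fold higher number from compound 1 to compound 3 (0.49 log units; beyond the scatter). The earlier compounds showed only one five-membered aromatic ring exchanged for another at this position, whereas these steps show that the ring-free methylcarbamoyl sits higher than both, by an amount that can only be bounded from one side: the limit of > 10000 nM in this assay, at which 1 of the 3 values shown sits.

Whether the loss of the ring or the methylcarbamoyl itself lies behind this rise stays open. A pyridyl ring, a plain methyl or a carboxylic acid on the same aromatic carbon would help to separate the two.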